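Octyl to butyl: a step between limits

This account rests on a few compounds, and the source may have more. Where it says the series, first, only, none or still open, it means among the compounds named here.

Measured in an ADME assay on U2OS cells (Homo sapiens) for cytotoxicity; a higher number here means that more compound is tolerated, a lower number that less compound is tolerated:
Compound 1 `CC(C)(C)c1ccc(C(=O)N/N=C/c2ccc([N+](=O)[O-])o2)cc1`: > 200000 nM (a limit)
Compound 2 `CCCCCCCCc1ccc(C(=O)N/N=C/c2ccc([N+](=O)[O-])o2)cc1`: > 200000 nM (a limit)

Compound 2 stands only at a limit, > 200000 nM, and gives no number. Among the compounds with values here, the one measured step, a step that the two limits leave unreadable from compound 1 to compound 2, has no readable size, and the limit of > 200000 nM in this assay, at which 2 of the 2 values shown sit, is all that bears on the next change. Compound 3 `CCCCc1ccc(C(=O)N/N=C/c2ccc([N+](=O)[O-])o2)cc1` differs from compound 2 by hydrogen in place of butyl on a saturated chain carbon, four bonds along the chain from an aromatic carbon. With a step that the two limits leave unreadable from compound 1 to compound 2 unreadable, no step beyond the scatter is expected in this assay. The estimated step is a number no higher from compound 2 to compound 3 (the limit leaves the size open). Compound 3 is expected at 200000 nM, with an estimated range from 120000 nM to 300000 nM.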

Compound 3, half-maximal cytotoxic concentration: 19600 nM
Beside the measured number, compound 3's estimate is 10-fold (1.01 log units) above it; measured number below the stated range.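

In this assay, hydrogen in place of butyl on a saturated chain carbon, four bonds along the chain from an aromatic carbon, gives an at least 10-fold lower number from compound 2 to compound 3 (1.00 log units; beyond the scatter), so this change has a readable effect beyond the scatter. Exchanging the tert-butyl group for butyl gives an at least 10-fold lower number from compound 1 to compound 3 (1.00 log units; beyond the scatter), which sets compound 3 apart from both earlier compounds. Both sizes are only minimums, because compound 1 and compound 2 stand at a limit: the limit of > 200000 nM in this assay, at which 2 of the 3 values shown sit.

The step between those two compounds still cannot be read. Where a hexyl chain, or an amine in place of butyl, would fall remains open.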